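The source may report more compounds than this note shows. Statements on the series, on what has been measured and on what is new or still open speak of the compounds shown alone.

Measured so far:
Compound 1, `ClCc1ccc(Cn2cnc3c(Cl)ncnc32)cc1`, in a functional assay on NCI-H226 cells (Homo sapiens) for cytotoxicity, read by sulforhodamine B assay, with a stated time of 48 h (a lower number here means a stronger inhibitor of growth, a higher number a weaker inhibitor of growth), gives 7410 nM.
Compound 2, `ClCc1ccccc1Cn1cnc2c(Cl)nc(Cl)nc21`, in this assay gives 3380 nM.

Of these two numbers, compound 1 has the higher one, meaning it is the weaker inhibitor of growth. Going by the values given here, its only neighbour is compound 2, whose number is lower by a margin beyond the usual scatter of repeated measurements. Among the compounds with values here, the two compounds differ in more than one place, so their values alone say nothing about what any single change contributes; they show only that compound 2 inhibits growth more strongly than compound 1.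

Compound 3, `ClCc1ccc(Cn2cnc3c(Cl)nc(Cl)nc32)cc1`, has not yet been measured. It differs from compound 1 in one respect: chloro in place of hydrogen on an aromatic carbon. Within the data shown here, no pair of measured compounds isolates this change, so its size has to be guessed. Because compound 2, which also carries two chloro groups on the core, gives 3380 nM, a modest move towards a lower number is expected rather than no change. The expected step from compound 1 to compound 3 is a 2.1-fold lower number from compound 1 to compound 3 (0.33 log units; beyond the scatter). Compound 3 is therefore estimated at 3500 nM, within a range from 1200 nM to 10000 nM.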

Compound 3, concentration for total growth inhibition: 9550 nM
Estimate against measurement, compound 3: 2.7-fold (0.44 log units) below, within the range that was stated.
By their numbers in this assay, from the lowest: compound 2; then compounds 1 and 3 (each within the scatter of the next).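

In this assay, going by these compounds alone, the one direct reading of this change is a 1.3-fold higher number from compound 1 to compound 3 (0.11 log units; within the scatter) and so the swap of hydrogen for chloro leaves the number where it was, as far as this assay can resolve. The carbon concerned lies between two ring nitrogen atoms on the core, and this single added chlorine atom produces no change in growth inhibition that stands clear of ordinary measurement noise. No measurement bearing on why this substitution is so quiet is available here.

What this single pair cannot say is whether the quiet result belongs to this carbon in general or to chloro alone, since a different group here, such as an amine, a methoxy group or a longer chain, might shift the number in either direction. It also leaves open whether the same swap would stay as quiet on a compound whose chloromethyl group sits elsewhere, or on other cell lines.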